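Halophenyl exchange in the series and tolerated concentration

This account rests on a few compounds, and the source may have more. Where it says the series, first, only, none or still open, it means among the compounds named here.

Measured so far:
Compound 1, `Brc1cccc(Cc2nnc(Cn3nnc4ccccc43)o2)c1`. In an ADME assay on cells (Macrophage, Homo sapiens) for inhibition (a lower number here means that less compound is tolerated, a higher number that more compound is tolerated), compound 1 gives > 100000 nM, a limit of the assay rather than a number.
Compound 2, `Brc1ccc(Cc2nnc(Cn3nnc4ccccc43)o2)cc1`. In this assay compound 2 gives > 100000 nM, again a limit of the assay and not a number.

Compound 2 therefore stands at a limit in this assay, with no number of its own to place it. Going by the values given here, the one measured step, a step that the two limits leave unreadable from compound 1 to compound 2, cannot be read because both ends of it sit at the limit; what is known is the limit of > 100000 nM in this assay, at which 2 of the 2 values shown sit.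

Compound 3, `Clc1cccc(Cc2nnc(Cn3nnc4ccccc43)o2)c1`, has not yet been measured in this assay. Its change from compound 2 is 3-chlorophenyl in place of 4-bromophenyl on a saturated chain carbon bound to an aromatic carbon. Among the compounds with values here, the single measured step in this assay, which exchanged the position of the same halogen, gave no readable size, and the two values shown give no sign that any halophenyl variant reaches a measurable number. No step beyond the scatter is expected for compound 3 in this assay, and the most probable outcome is that compound 3 is also reported as a limit. The estimate for compound 3 in this assay is 100000 nM, within 50000 nM to 200000 nM. The step this estimate means for compound 3 is a number no higher from compound 2 to compound 3 (the limit leaves the size open), expected to stay within the scatter.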

Compound 3, half-maximal cytotoxic concentration: > 100000 nM
Compound 3: a limit, no number; the forecaster's own chance of this, stated with the estimate: 85%; the middle value lies on the limit itself.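

Neither step ending at compound 3, from compound 1 or from compound 2, can be read in this assay: the limit of > 100000 nM in this assay, at which 3 of the 3 values shown sit.

The compounds shown leave open how far compound 1, compound 2 and compound 3 differ in tolerated concentration, and whether any halophenyl exchange on the shared core gives a measurable number in this assay.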